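The source may report more compounds than this note shows. Statements on the series, on what has been measured and on what is new or still open speak of the compounds shown alone.

Compound 1 (`O=c1oc2ccccc2c2nc3c(ccc4cc[nH]c43)c(-c3cccc4ccccc34)c12`) carries a naphthalen-1-yl group on its core. In a functional assay on B16-F10 cells (Mus musculus) for cytotoxicity (on this read-out higher numbers stand for weaker inhibition and lower numbers for stronger inhibition), compound 1 gives 70700 nM. Within the data shown here, only one other compound has been measured so far, and compound 2 (`O=c1cc(O)c2cc(F)ccc2o1`) stands level with it at 70700 nM. Among the measured compounds shown here, that pair offers no measured step, so nothing yet shows how a change to compound 1 moves the number in this assay.

Compound 3 (`O=c1oc2ccccc2c2nc3c(ccc4cc[nH]c43)c(-c3ccccn3)c12`) keeps the core of compound 1 and changes one group: pyridin-2-yl in place of naphthalen-1-yl on an aromatic carbon, opposite the ring nitrogen (pyridin-2-yl in place of naphthalen-1-yl on an aromatic carbon). For the measured compounds named here, no measured pair tests this swap, so any forecast is rough. A modest move towards stronger inhibition is expected, although a result within the usual scatter would be no surprise. The direction rests on one observation: compound 1 at 70700 nM shows weak inhibition, which leaves more room for the number to fall than to rise. The expected change is a 2.0-fold lower number from compound 1 to compound 3 (0.31 log units; beyond the scatter). For compound 3, the estimated value is 35000 nM, with an expected range of 9000 nM to 110000 nM.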

Compound 3, half-maximal inhibitory concentration: 70700 nM
The estimate for compound 3 lay 2.0-fold (0.31 log units) below the measured number; the measured number falls inside the stated range.
By their numbers in this assay, from the lowest: compounds 1, 2 and 3 (each within the scatter of the next).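

Among these compounds, the first measured step at this position, on an aromatic carbon opposite the ring nitrogen, reads no change at the digits printed from compound 1 to compound 3 (within the scatter) in this assay and comes from putting pyridin-2-yl in place of naphthalen-1-yl. The group shrinks from 10 heavy atoms to 6, loses one of its two aromatic rings and gains a ring nitrogen that counts as a hydrogen-bond acceptor, yet this large change in the group leaves the read-out where it was. No supporting measurement is available to explain why the number holds steady here.

As far as these compounds go, what remains open is whether any group at this position can move the number at all, for instance an amine, a carboxylic acid or a longer alkyl chain in place of the aromatic ring. A plain phenyl group at the same carbon would also help, since it would separate the effect of losing the second ring from the effect of adding the ring nitrogen.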